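Hydrogen in place of amino on a shared core

A few compounds are considered here, and "the series" means these few. Any claim that something is new, unique, unknown or untested is made for them only; others in the source may bear on it.

Compound 1 `Nc1nc(Cl)c2ncn(Cc3ccccc3CCl)c2n1`: > 100000 nM
Compound 2 `ClCc1ccccc1Cn1cnc2nc(Cl)nc(Cl)c21`: "not determined" (no result reported)
Compound 3 `Nc1nc(Cl)c2ncn(Cc3cccc(CCl)c3)c2n1`: > 100000 nM

The three compounds were studied in a functional assay on RPMI-8226 cells (Homo sapiens) for cytotoxicity, read by sulforhodamine B assay, with a stated time of 48 h; on this read-out lower numbers stand for higher toxicity in this test and higher numbers for lower toxicity in this test. Compound 1 gives > 100000 nM, which is a limit of this assay and not a number. Compound 3 gives > 100000 nM, again a limit. For compound 2 the result is "not determined" (no result reported). Among the compounds with values here, compound 1 therefore stands at the limit together with compound 3, and no numbered value exists among the three; the only evidence is the limit of > 100000 nM in this assay, at which 2 of the 3 values shown sit.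

Compound 4 `ClCc1ccccc1Cn1cnc2c(Cl)ncnc21` has not yet been measured. It differs from compound 1 in a single place: hydrogen in place of amino on an aromatic carbon. Within the data shown here, no step between measured compounds is available to calibrate this change. Because the two values reported both sit at the limit of > 100000 nM in this assay, at which 2 of the 3 values shown sit, the cytotoxicity of compound 4 is expected to remain in the same region as that of compound 1. The expected step from compound 1 to compound 4 is a number no higher from compound 1 to compound 4 (the limit leaves the size open), none beyond the usual scatter. Compound 4 is thus estimated to give 100000 nM in this assay, within a range from 30000 nM to 300000 nM, and most probably the assay will again report only a limit.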

Compound 4, concentration lethal to 50% of the cells: > 100000 nM
Compound 4: only a limit was reported (the forecaster's own chance of this, stated with the estimate: 75%); the middle value sits exactly at the limit.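

No step can be read from compound 1 to compound 4 in this assay, because both results are limits of the assay and not numbers: the limit of > 100000 nM in this assay, at which 3 of the 4 values shown sit.

The compounds shown leave open how far hydrogen in place of amino on an aromatic carbon shifts cytotoxicity, if it shifts it at all.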